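Working notes: replacing benzyloxy with (4-methoxyphenyl)amino

This account rests on a few compounds, and the source may have more. Where it says the series, first, only, none or still open, it means among the compounds named here.

Measured in an ADME assay on HEK293 cells (Homo sapiens) for cytotoxicity, with a stated time of 72 h (on this read-out higher numbers stand for an effect only at larger amounts of compound and lower numbers for an effect already at smaller amounts), as limits of the assay
compound 1 `C=C[C@@](C)(/C=C/c1ccc(OCc2ccccc2)cc1)CCC=C(C)C` gives > 36600 nM
compound 2 `C=C[C@@](C)(/C=C/c1ccc(O)c(/C=C/C(N)=O)c1)CCC=C(C)C` gives > 36600 nM
compound 3 `CCOC(=O)/C=C/c1cc(/C=C/[C@](C)(/C=C/c2ccc(OC)cc2)CCC=C(C)C)ccc1O` gives > 36600 nM

Compound 1 stands at a limit (> 36600 nM) and has no actual number. Within the data shown here, the three measured compounds share one reading (the limit of > 36600 nM in this assay, at which 3 of the 3 values shown sit) and no step between them can be stated. The series therefore gives no direct measure of how far a change on the shared core can move this read-out.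

Compound 4 (`C=C[C@@](C)(/C=C/c1ccc(Nc2ccc(OC)cc2)cc1)CCC=C(C)C`) is the open case. Its difference from compound 1 ((4-methoxyphenyl)amino in place of benzyloxy on an aromatic carbon) is (4-methoxyphenyl)amino in place of benzyloxy on an aromatic carbon, para to a large group. Among the measured compounds shown here, none of the measured compounds carries this group. The expected move (an at least 1.4-fold lower number from compound 1 to compound 4 (0.16 log units; that floor lies within the scatter)) is estimated as modest and toward lower numbers. A further report of only a limit is also expected to be quite possible. Compound 4 is expected at 25000 nM (estimated range 8000 nM to 60000 nM).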

Compound 4, half-maximal effective concentration: > 36600 nM
Compound 4: only a limit was reported; the forecaster's own chance of this, stated with the estimate: 55%; middle value at least 1.4-fold (0.16 log units) from the limit.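

Compound 1 and compound 4 both give only a limit, so no step between them can be read; the shared reading is: the limit of > 36600 nM in this assay, at which 4 of the 4 values shown sit.

The compounds shown leave open whether (4-methoxyphenyl)amino in place of benzyloxy, or any other change on the shared core, moves this read-out at all.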